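From compound 2 to compound 3: a smaller group on nitrogen

This account rests on a few compounds, and the source may have more. Where it says the series, first, only, none or still open, it means among the compounds named here.

Values so far in a physicochemical assay for lipophilicity, using the shake flask method, measured as octanol-water partition, at pH 7.4 (a higher number here means a more lipophilic compound, a lower number a more polar compound), are these
- compound 1 `C[C@@H](Nc1c(C(N)=O)cnc2ccc(C#N)cc12)c1ccc(Cl)cc1` gives 3.5 as a number
- compound 2 `C[C@@H](Nc1c(C(N)=O)cnc2ccc(-c3cccnc3)cc12)c1ccc(Cl)cc1` gives > 4.3 as a limit

Compound 2 stands at the limit of > 4.3 in this assay, at which 1 of the 2 values shown sits, and so has a limit, not a number. Compound 3 `NC(=O)c1cnc2ccc(-c3cccnc3)cc2c1NC1CCCC1` differs from it by cyclopentyl in place of 1-(4-chlorophenyl)ethyl on a nitrogen on an aromatic ring in one place: cyclopentyl in place of 1-(4-chlorophenyl)ethyl on a nitrogen on an aromatic ring. Among the measured compounds shown here, the only measured step is a number at least 0.80 log units higher from compound 1 to compound 2 (beyond the scatter) with pyridin-3-yl in place of cyano on an aromatic carbon. That step changed another place and serves only as a rough scale. With the smaller group entering, a downward move is expected in this assay of a size beyond the scatter. The estimated change is a number at least 1.00 log units lower from compound 2 to compound 3 (beyond the scatter) in this reading. For compound 3 the expected value is 3.3 within a range of 2.7 to 3.9 on this estimate.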

Compound 3, distribution coefficient: 3.6
The estimate for compound 3 lay 0.30 log units below the measured number, and the stated range covers the measured number.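

In this assay, among the compounds shown here, the earlier compounds showed a change only on an aromatic carbon, whereas this result shows that the group on a nitrogen on an aromatic ring also moves the read-out: cyclopentyl in place of 1-(4-chlorophenyl)ethyl gives a number at least 0.70 log units lower from compound 2 to compound 3 (beyond the scatter). The full size of this step cannot be given because compound 2 carries a limit and not a number: the limit of > 4.3 in this assay, at which 1 of the 3 values shown sits.

From the compounds shown here alone, whether cyclopentyl would give a similar step alongside the cyano group of compound 1 remains open. So does the effect of a longer chain, such as hexyl, or an amine, such as piperidine, on this nitrogen.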